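The source may hold more compounds than are shown below. What is called first, only, known or untested is meant among the compounds shown, and "the series" means these compounds.

In a functional assay on HEK293 cells (Homo sapiens) for cytotoxicity (a lower number here means that less compound is tolerated, a higher number that more compound is tolerated), compound 1 (`COc1ccc([C@H]2CC(=O)N(c3ccccc3)C2)cc1OC1CCCC1`) gives > 10000 nM, which is a limit and not a number. Compound 2 (`COc1ccc([C@H]2CC(=O)N(c3cccc(O)c3)C2)cc1OC1CCCC1`) gives > 10000 nM, again a limit. Compound 3 (`COc1ccc([C@H]2CC(=O)N(c3ccccn3)C2)cc1OC1CCCC1`) gives > 10000 nM, also a limit, so it has no numerical reading and no rank within the series. The data so far show only (the limit of > 10000 nM in this assay, at which 3 of the 3 values shown sit).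

Compound 4 (`COc1ccc([C@H]2CC(=O)N(c3ccncc3)C2)cc1OC1CCCC1`) carries pyridin-4-yl in place of pyridin-2-yl on an amide-type nitrogen in a ring. The closest measured changes at this nitrogen are a step that the two limits leave unreadable from compound 1 to compound 3 and a step that the two limits leave unreadable from compound 2 to compound 3. The hydroxy change gives a step that the two limits leave unreadable from compound 1 to compound 2. Within the data shown here, none of these provides a size or a direction, and no measured step tests this exchange of pyridinyl groups directly. A step beyond the scatter is therefore not expected, and the working assumption is that the series stays at the same limit. The expected change is a step that the limit leaves unreadable from compound 3 to compound 4. For compound 4 the estimated value is 15000 nM, with an expected range of 6000 nM to 40000 nM.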

Compound 4, half-maximal cytotoxic concentration: > 10000 nM
Compound 4: only a limit was reported; the forecaster's own chance of this, stated with the estimate: 90%; the middle value lies beyond the limit too.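

No new step can be read between compound 4 and compound 1, compound 2 or compound 3, since all four rest on one limit: the limit of > 10000 nM in this assay, at which 4 of the 4 values shown sit.

In this assay the compounds shown leave open where each would read as a number, and whether the groups on the amide-type nitrogen differ at all.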